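Phenyl to pyridin-2-yl: an efficacy estimate

This account rests on a few compounds, and the source may have more. Where it says the series, first, only, none or still open, it means among the compounds named here.

Three measured compounds share one core. Compound 1 `O=C(O)Cc1sc(C(c2ccccc2)c2ccc(Cl)cc2)nc1-c1ccc(Cl)cc1` reaches 80% in an in vitro functional assay on HEK285-7 cells for antagonist activity at prostaglandin D2 receptor 2 (Homo sapiens), read by BRET and beta-arrestin recruitment; a higher number here means a larger maximal response, a lower number a smaller maximal response. Compound 2 `O=C(O)Cc1sc(C(c2ccccc2)c2ccc(F)cc2)nc1-c1ccc(Cl)cc1` reaches 80%, and compound 3 `COc1ccc(C(c2ccccc2)c2nc(-c3ccc(Cl)cc3)c(CC(=O)O)s2)cc1` reaches 80%. The steps among them, no change at the digits printed from compound 1 to compound 2 (within the scatter), no change at the digits printed from compound 1 to compound 3 (within the scatter) and no change at the digits printed from compound 2 to compound 3 (within the scatter), all stay within the scatter, so compound 3 stands level with compounds 1 and 2.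

Compound 4 `COc1ccc(C(c2ccccn2)c2nc(-c3ccc(Cl)cc3)c(CC(=O)O)s2)cc1` differs from compound 3 by pyridin-2-yl in place of phenyl on a saturated chain carbon bound to two aromatic carbons. Going by the values given here, none of the measured steps touches that position; all three swapped a substituent on an aromatic carbon and left the maximal response unchanged. With nothing pointing either way, compound 4 is expected to show no step beyond the scatter, no change at the digits printed from compound 3 to compound 4 (within the scatter). The estimate for compound 4 is 80%, expected between 62% and 95%.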

Compound 4, largest response reached (reported as efficacy), in percent of the reference or control that the assay uses: 80%
Compound 4: middle estimate and measured number agree at the digits printed, within the range that was stated.
By their numbers in this assay, from the lowest: compounds 1, 2, 3 and 4 (each within the scatter of the next).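

The earlier steps shown here all swapped a substituent on an aromatic carbon, whereas this one changes a whole ring on the saturated chain carbon bound to two aromatic carbons. In this assay pyridin-2-yl in place of phenyl gives no change at the digits printed from compound 3 to compound 4 (within the scatter) even though the entering ring brings a ring nitrogen and a hydrogen-bond acceptor. Nothing available explains this result.

Going by these compounds, whether an amine or a carboxylic acid on that carbon would give the same maximal response stays open. So does whether pyridin-2-yl behaves alike with chloro or fluoro in place of methoxy.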